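The source may report more compounds than this note shows. Statements on the series, on what has been measured and on what is new or still open speak of the compounds shown alone.

Measured in a functional assay on Ehrlich cells (Mus musculus) for cytotoxicity, tested at 25 ug/mL; on this read-out higher numbers stand for a stronger effect at the one concentration tested and lower numbers for a weaker effect:
compound 1, `COc1ccc(C2C(C#N)=C(N)N(c3cc(OC)c(OC)c(OC)c3)C3=C2C(=O)CC(C)(C)C3)cc1`, gives 1%;
compound 2, `COc1cc(N2C(N)=C(C#N)C(c3c(O)ccc4ccccc34)C3=C2CC(C)(C)CC3=O)cc(OC)c1OC`, gives 10%;
compound 3, `COc1cc(N2C(N)=C(C#N)C(c3ccc(C)cc3)C3=C2CC(C)(C)CC3=O)cc(OC)c1OC`, gives 50%.

Compound 1 gives the lowest of the three numbers, though its nearest neighbour, compound 2, lies a number 9 percentage points higher from compound 1 to compound 2 (within the scatter), which is no real separation. Compound 3 stands a number 49 percentage points higher from compound 1 to compound 3 (beyond the scatter), and the step of a number 40 percentage points higher from compound 2 to compound 3 (beyond the scatter) is likewise large. Compound 4, `COc1cc(N2C(N)=C(C#N)C(c3ccc(O)cc3)C3=C2CC(C)(C)CC3=O)cc(OC)c1OC`, has yet to be measured in this assay. It differs from compound 1 in one place: hydrogen in place of methyl on an oxygen on an aromatic ring. Going by the values given here, no measured pair swaps methoxy for hydroxy, so nothing directly fixes the size of this step. Among the compounds with values here, the only change made at the same methoxy group is in compound 3, where methyl replaces it and the read-out moves far, a number 49 percentage points higher from compound 1 to compound 3 (beyond the scatter); this shows that the group at this place can shift the number a great deal, but not whether hydroxy shifts it in the same direction. The expectation for compound 4 is therefore a moderate rise from compound 1, a number 14 percentage points higher from compound 1 to compound 4 (beyond the scatter), held with a wide range. Compound 4 is estimated at 15%, expected to lie between 0% and 45%.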

Compound 4, a percentage reported as activity, at one concentration (the size of the read-out at that concentration, not a potency): 20%
Estimate against measurement, compound 4: 5 percentage points below; the measured number falls inside the stated range.
By their numbers in this assay, from the lowest: compounds 1, 2 and 4 (each within the scatter of the next, the first and the last beyond it); then compound 3.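

In this assay, going by these compounds alone, the exchange of methoxy for hydroxy on the aromatic ring moves the read-out on its own and beyond the scatter (a number 19 percentage points higher from compound 1 to compound 4 (beyond the scatter)), so the rise seen earlier with methyl at this place is no longer the only upward change from the 4-methoxyphenyl compound. Hydroxy does not match methyl, however (a number 30 percentage points lower from compound 3 to compound 4 (beyond the scatter)), while the 4-hydroxyphenyl compound cannot be told apart from the 2-hydroxynaphthalen-1-yl compound (a number 10 percentage points higher from compound 2 to compound 4 (within the scatter)), so at this place the methyl compound alone stands clearly apart from the other three. Nothing measured here accounts for this order among methyl, hydroxy and methoxy.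

Still open, as far as these compounds go, is whether a longer chain such as ethyl at this place would stay with methyl, and whether an amine or a carboxylic acid there would fall with hydroxy or move the number elsewhere. From the compounds shown here alone, since this assay reports the size of the effect at one concentration only, it also remains open whether the gap between methyl and hydroxy would persist as a difference in potency.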